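The source may report more compounds than this note shows. Statements on the series, on what has been measured and on what is new or still open speak of the compounds shown alone.

Measured compounds:

compound 1, `CC(C)(C)c1cc(C(=O)NCCC2CCN(Cc3ccccc3)CC2)cc(C(C)(C)C)c1O`, 109000 nM in an assay on isolated protein for inhibition of Amine oxidase [flavin-containing] A (Homo sapiens), read by fluorescence, with stated times of 15 min and 20 min; on this read-out lower numbers stand for stronger inhibition and higher numbers for weaker inhibition
compound 2, `CC(C)(C)c1cc(/C=C/C(=O)NC2CCN(Cc3ccccc3)CC2)cc(C(C)(C)C)c1O`, 42500 nM in this assay
compound 3, `CC(C)(C)c1cc(/C=C/C(=O)NCCC2CCN(Cc3ccccc3)CC2)cc(C(C)(C)C)c1O`, 62300 nM in this assay

All three compounds share the same core and give numbers in this assay that lie close to one another. Compound 3 sits between the other two: its gap to compound 2 falls within the scatter, and so does its gap to compound 1, so nothing among these three can be called stronger or weaker than another.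

Compound 4, `Cc1ccc(CN2CCC(CCNC(=O)/C=C/c3cc(C(C)(C)C)c(O)c(C(C)(C)C)c3)CC2)cc1`, has not yet been measured in this assay. It differs from compound 3 in one place: methyl in place of hydrogen on an aromatic carbon. Among the measured compounds shown here, no pair among the measured compounds shows this change, so there is no measured step to lean on. The three numbers already seen vary little despite larger changes in the linker, and the added methyl is a single carbon, so the expected step is none beyond the scatter. The estimated step from compound 3 to compound 4 in this assay is a 1.1-fold lower number from compound 3 to compound 4 (0.05 log units; within the scatter). Compound 4 is therefore expected to give about 55000 nM in this assay, in a range from 25000 nM to 120000 nM.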

Compound 4, half-maximal inhibitory concentration: 70100 nM
Beside the measured number, compound 4's estimate is 1.3-fold (0.11 log units) below it; measured number inside the range.
By their numbers in this assay, from the lowest: compounds 2, 3, 4 and 1 (each within the scatter of the next, the first and the last beyond it).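

In this assay, the change from benzyl to 4-methylbenzyl gives a 1.1-fold higher number from compound 3 to compound 4 (0.05 log units; within the scatter), so a methyl on this aromatic carbon, para to a large group, leaves the number within the scatter. Among the compounds shown here, this is the first measured step that isolates this ring position, and it shows that this one added carbon does not separate compound 4 from compound 3. No measurement offered here explains this result.

As far as these compounds go, whether a chlorine, a methoxy group or a carboxylic acid on the same aromatic carbon would move the number beyond the scatter remains open. Also open, from the compounds shown here alone, is whether the same methyl would give a step of similar size on compound 2, which carries a different linker.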